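Adenosine A2b binding: removing a methyl from compound 3

A few compounds are considered here, and "the series" means these few. Any claim that something is new, unique, unknown or untested is made for them only; others in the source may bear on it.

Measured so far in an assay on HEK293 cells for displacement of a labelled ligand from adenosine receptor A2b (Homo sapiens), read by scintillation counting, with a stated time of 30 min, tested at 10 uM; on this read-out lower numbers stand for less inhibition and higher numbers for more inhibition at the one concentration tested (going by the name of the read-out):
- compound 1 `NC(=O)c1nc(-c2ccccc2O)nc2c1ncn2Cc1ccccc1`: 9.5%
- compound 2 `Cc1ccc(-c2nc(C(=O)Nc3ccccn3)c3n2CCCCC3)cc1`: 19%
- compound 3 `CCO/C(C)=N/c1c(C#N)ncn1Cc1ccccc1`: 9.9%

Among the compounds with values here, the three compounds share no single core, and no pair differs in only one place. Compound 3 sits close to compound 1, and its gap to compound 2 also lies within the usual scatter of repeated measurements, so the three numbers cannot be ordered against one another on this assay.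

Within the data shown here, compound 4 `CCO/C=N/c1c(C#N)ncn1Cc1ccccc1` is the only pair-wise neighbour of compound 3. The change is a group of 5 heavy atoms (3 carbon, 1 nitrogen, 1 oxygen; no ring) in place of a group of 6 heavy atoms (4 carbon, 1 nitrogen, 1 oxygen; no ring), on an aromatic carbon. It sits on an aromatic carbon of a five-membered aromatic ring, next to the ring nitrogen and next to the ring atom that bears a cyano group.

Among the measured compounds shown here, since no measured pair shows what such a change does, the expectation rests on compound 3 alone. The step of a number 0.1 percentage points higher from compound 3 to compound 4 (within the scatter) is expected to be none beyond the scatter in this assay. Compound 4 is estimated at 10%, within 0% to 22%.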

Compound 4, a percentage reported as inhibition, at one concentration (the size of the read-out at that concentration, not a potency): 2%
Estimate against measurement, compound 4: 8 percentage points above; the measured number falls inside the stated range.
By their numbers in this assay, from the lowest: compounds 4, 1, 3 and 2 (each within the scatter of the next, the first and the last beyond it).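

In this assay, the group of 5 heavy atoms in place of the group of 6 heavy atoms, on the aromatic carbon next to the ring nitrogen, gives a number 7.9 percentage points lower from compound 3 to compound 4 (within the scatter). Within the data shown here, this is the first pair that differs in one place, and on this read-out the step does not separate the two compounds. No supporting data bear on the origin of this step.

Going by these compounds, whether an amine or a longer chain in place of this group would give a step beyond the scatter remains open. Also open, on these data alone, is whether the same change on another core would give a step of similar size.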